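Working notes: from compound 1 to compound 3

The compounds below may be only part of what the source reports. "The series", "measured", "known", "first", "only" and "open" are said of these compounds alone.

Measured in a functional assay on SH-SY5Y cells (Homo sapiens) for cytotoxicity, read by MTT assay, with a stated time of 56 h (a higher number here means that more compound is needed for the effect, a lower number that less compound is needed), so far
compound 1 `O=C(CCCCCCCc1cc(-c2cccnc2)on1)Nc1ccccc1-c1ccccc1` gives 59.8 nM
compound 2 `O=C(CCCCCCCc1nnc(-c2cccnc2)o1)Nc1ccccc1-c1ccccc1` gives 370 nM

Compound 1 has the lower of the two numbers, and its gap to compound 2 lies beyond the scatter. Compound 3 `O=C(CCCCCCCc1cnc(-c2cccnc2)s1)Nc1ccccc1-c1ccccc1` is still to be measured. It carries 2-(pyridin-3-yl)-1,3-thiazol-5-yl in place of 5-(pyridin-3-yl)-1,2-oxazol-3-yl on a saturated chain carbon, seven bonds along the chain from a carbonyl carbon.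

Among the compounds with values here, one measured step bears on this change. That modest step (a 6.2-fold higher number from compound 1 to compound 2 (0.79 log units; beyond the scatter)) exchanges the same group at the same place. Within the data shown here, no measured compound carries the thiazolyl group, so a single step gives only a rough guide to size and direction. On the evidence of that step (a 6.2-fold higher number from compound 1 to compound 2 (0.79 log units; beyond the scatter)), a rise of similar or smaller size is expected in this assay for compound 3, although no change beyond the scatter remains possible. The estimate for compound 3 means a 2.3-fold higher number from compound 1 to compound 3 (0.37 log units; beyond the scatter) as an expected change. In this assay compound 3 is estimated at 140 nM with an expected range from 40 nM to 500 nM around that figure.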

Compound 3, half-maximal effective concentration: 5250 nM
Compound 3: the middle estimate sits 38-fold (1.57 log units) below what was measured, outside the stated range (above it).
By their numbers in this assay, from the lowest: compound 1; then compound 2; then compound 3.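

In this assay, within the data shown here, the group on a saturated chain carbon, seven bonds along the chain from a carbonyl carbon, tolerates exchange far less than the first pair of compounds suggested: 2-(pyridin-3-yl)-1,3-thiazol-5-yl gives an 88-fold higher number from compound 1 to compound 3 (1.94 log units; beyond the scatter), and measured against the oxadiazolyl group it gives a 14-fold higher number from compound 2 to compound 3 (1.15 log units; beyond the scatter). The groups of compound 1 and compound 3 match in heavy atom count, ring types and counts of hydrogen-bond donors and acceptors, so none of these counts separates them, and the large step arises with sulfur in place of oxygen and a different arrangement of the five-membered ring. No measurement is available to explain the size of this step.

From the compounds shown here alone, it remains open whether the sulfur or the arrangement of the ring atoms accounts for the step, a question that a 2-(pyridin-3-yl)-1,3-oxazol-5-yl group at the same place would help to separate. Going by these compounds, it is also open whether the order of the three five-membered rings would hold with a phenyl ring in place of the pyridin-3-yl ring, or with a shorter chain.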